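Replacing a cyclopropyl with a 4-fluoro-3-methylphenyl group

The source may report more compounds than this note shows. Statements on the series, on what has been measured and on what is new or still open speak of the compounds shown alone.

Compound 1 `CC(C)CCN1C(=O)C(C2=NS(=O)(=O)c3cc(NS(C)(=O)=O)ccc3N2)=C(O)[C@H]2CCC[C@H]21`: 0.383 h
Compound 2 `CS(=O)(=O)Nc1ccc2c(c1)S(=O)(=O)N=C(C1=C(O)[C@H]3CCC[C@H]3N(CC3CC3)C1=O)N2`: > 1 h

In an in vitro ADME assay on microsomes from liver (Homo sapiens) for metabolic stability (a lower number here means that the compound disappears faster, a higher number that the compound lasts longer), compound 1 gives 0.383 h. Compound 2 reaches only a limit of this assay, > 1 h, as noted at the limit of > 1 h in this assay, at which 1 of the 2 values shown sits. Among the compounds with values here, the one measured step, an at least 2.6-fold higher number from compound 1 to compound 2 (0.41 log units; beyond the scatter), is the only guide here, and it stops at a limit, so the true size of that gain is not known.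

Compound 3 `Cc1cc(CN2C(=O)C(C3=NS(=O)(=O)c4cc(NS(C)(=O)=O)ccc4N3)=C(O)[C@H]3CCC[C@H]32)ccc1F` carries a larger change: 4-fluoro-3-methylphenyl in place of cyclopropyl on a saturated chain carbon bound to an amide-type nitrogen in a ring. Within the data shown here, no measured step covers a swap of a small carbon ring for a substituted aromatic ring at this position, so the direction cannot be read from the data; a fall back toward compound 1 is as plausible as holding the level of compound 2. The estimate for compound 3 is therefore a half-life of 0.7 h, between 0.3 h and 1.6 h, which would mean an expected step of an at least 1.4-fold lower number from compound 2 to compound 3 (0.15 log units; that floor lies within the scatter).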

Compound 3, half-life: > 1 h
Compound 3: a limit, no number (the forecaster's own chance of this, stated with the estimate: 35%); middle value at least 1.4-fold (0.15 log units) from the limit.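

In this assay compound 3 reaches only a limit, > 1 h, and not a number. Swapping the isobutyl on the saturated chain carbon bound to an amide-type nitrogen in a ring for a much larger 4-fluoro-3-methylphenyl gives an at least 2.6-fold higher number from compound 1 to compound 3 (0.41 log units; beyond the scatter), so the gain seen with cyclopropyl is not confined to a small carbon ring and also appears with an aromatic ring. The step between compound 2 and compound 3 cannot be read, and the limit of the assay is what hides it: the limit of > 1 h in this assay, at which 2 of the 3 values shown sit.

From the compounds shown here alone, how far either compound lasts past that limit stays open, and so does which of the two rings lasts longer. Also open, going by these compounds, is whether a plain benzyl without the fluorine and methyl, or a chain ending in an amine or a carboxylic acid, would keep this gain.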